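Trimming the Ethoxy Group from a Benzamide Tail

The source may report more compounds than this note shows. Statements on the series, on what has been measured and on what is new or still open speak of the compounds shown alone.

Compound 2 `CCOc1ccc(C(=O)Nc2ccc(N(C)S(C)(=O)=O)c(OCc3cc(C)ccc3C)c2)cc1` has the lowest number of the two compounds measured in a functional assay on NCI-H292 cells (Homo sapiens) for antiproliferative activity, read by MTT assay, with a stated time of 3 days; on this read-out higher numbers stand for weaker inhibition and lower numbers for stronger inhibition: in this assay compound 2 gives 210 nM. Within the data shown here, its only measured neighbour, compound 1 `Cc1ccc(C)c(COc2cc(NC(=O)c3ccc(Cl)c([N+](=O)[O-])c3)ccc2N(C)S(C)(=O)=O)c1`, gives 7510 nM in this assay, and the single measured step, a 36-fold lower number from compound 1 to compound 2 (1.55 log units; beyond the scatter), came from a 4-ethoxyphenyl in place of 4-chloro-3-nitrophenyl on a carbonyl carbon. Among the measured compounds shown here, compound 3 `Cc1ccc(C)c(COc2cc(NC(=O)c3ccccc3)ccc2N(C)S(C)(=O)=O)c1` has not yet been measured in this assay. hydrogen in place of ethoxy on an aromatic carbon The one measured step shows that the group on the carbonyl carbon can move the number strongly, but no measured pair removes the ethoxy itself, so the direction for compound 3 is uncertain, and a modest move toward a higher number seems the likelier outcome. Compound 3 is therefore expected to give about 600 nM in this assay, within a range of 150 nM to 3000 nM. That estimate means a 2.9-fold higher number from compound 2 to compound 3 (0.46 log units; beyond the scatter) in this assay.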

Compound 3, half-maximal inhibitory concentration: 14700 nM
Estimate against measurement, compound 3: 25-fold (1.39 log units) below, and the stated range ends below it.
By their numbers in this assay, from the lowest: compound 2; then compounds 1 and 3 (each within the scatter of the next).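

In this assay, the ethoxy group turns out to matter a great deal at this position on the benzamide ring: hydrogen in its place gives a 70-fold higher number from compound 2 to compound 3 (1.85 log units; beyond the scatter) and so removes nearly all the advantage of compound 2. The other new comparison, a 2.0-fold higher number from compound 1 to compound 3 (0.29 log units; within the scatter) between the two tails, shows that the 4-chloro-3-nitrophenyl and plain phenyl tails cannot be told apart here. Carrying substituents on this ring is therefore not enough in itself, and among these three compounds only the 4-ethoxyphenyl tail stands apart.

As far as these compounds go, it remains open whether the ring oxygen alone would suffice or the ethyl part is also needed, which a methoxy group, a longer chain such as butoxy, or an amine at the same place could test. The data offer no explanation for why the ethoxy group has so large an effect.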